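Ester in place of ether on the distal phenyl ring

This account rests on a few compounds, and the source may have more. Where it says the series, first, only, none or still open, it means among the compounds named here.

Measured so far in an assay on isolated protein for agonist activity at Bile acid receptor (Homo sapiens), read by AlphaScreen, with a stated time of 30 min; on this read-out higher numbers stand for an effect only at larger amounts of compound and lower numbers for an effect already at smaller amounts:
Compound 1 `Cc1ccccc1-n1nc(C)c2c1NC(=O)[C@H](C)S[C@@H]2c1ccc(-c2ccccc2)cc1`: 990 nM
Compound 2 `Cc1ccccc1-n1nc(C)c2c1NC(=O)[C@H](C)S[C@@H]2c1ccc(Oc2ccccc2C(=O)O)cc1`: "not active" (no number reported)
Compound 3 `CCOc1cccc(-c2ccc([C@H]3S[C@@H](C)C(=O)Nc4c3c(C)nn4-c3ccccc3C)cc2)c1`: 3500 nM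

Compound 3 has the highest number of the two reported for this assay; its nearest neighbour is compound 1, and the step of a 3.5-fold higher number from compound 1 to compound 3 (0.55 log units; beyond the scatter) is a modest one, beyond the scatter. Compound 2 gave no number at all in this assay.

Compound 4 `COC(=O)c1cccc(-c2ccc([C@H]3S[C@@H](C)C(=O)Nc4c3c(C)nn4-c3ccccc3C)cc2)c1` differs from compound 3 in one place: methoxycarbonyl in place of ethoxy on an aromatic carbon. Going by the values given here, no measured pair shows exactly this exchange. Among the compounds with values here, the only step that bears on it is the one from compound 1 to compound 3, where adding a group on that same ring carbon raised the number modestly; compound 4 keeps a group at that position and so is expected to remain in the region of compound 3 rather than return towards compound 1. A step of about a 1.1-fold higher number from compound 3 to compound 4 (0.06 log units; within the scatter) is expected, within or just at the edge of the scatter, and compound 4 is estimated at 4000 nM with a likely range of 1500 nM to 12000 nM.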

Compound 4, half-maximal effective concentration: "not active" (no number reported)
Nothing numeric was reported for compound 4, so the estimate cannot be set against anything.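

Going by these compounds alone, compound 4 is reported as not active in this assay without a number, so no step from compound 3 to compound 4 can be read. No evidence shown bears on this result. The compounds shown leave open whether any other group at that position keeps a measurable effect.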